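The source may hold more compounds than are shown below. What is called first, only, known or untested is meant among the compounds shown, and "the series" means these compounds.

Compound 1 `COc1ccc(COc2ccc(OCCOCCNC3CCCC3)cc2)cc1` gives 15700 nM in a functional assay on SK-OV-3 cells (Homo sapiens) for inhibition, read by CCK-8 assay, with a stated time of 70 h; on this read-out lower numbers stand for stronger inhibition and higher numbers for weaker inhibition.
Compound 3 `c1ccc(COc2ccc(OCCOCCNC3CCC3)cc2)cc1` gives 25000 nM in this assay.
Compound 2 `c1ccc(COc2ccc(OCCOCCOC3CCCC3)cc2)cc1` gives only > 100000 nM in this assay, which is a limit of the assay and not a number.

Among the two numbers, compound 1 has the lower one, and compound 3 lies within the usual scatter of it, so no order between them can be claimed. The limit of compound 2 is the limit of > 100000 nM in this assay, at which 1 of the 3 values shown sits. Going by the values given here, the one measured step, an at least 4.0-fold lower number from compound 2 to compound 3 (0.60 log units; beyond the scatter), changes the far end of the chain and does not bear on the change to compound 4 `COc1ccc(OCCOCCNC2CCCC2)cc1`, where (hydrogen in place of 4-methoxyphenyl on a saturated chain carbon bound to an oxygen on an aromatic ring). Among the compounds with values here, no measured step covers this change; the expectation rests only on how much of the structure leaves. Compound 4 is expected to give a weaker number, a 2.9-fold higher number from compound 1 to compound 4 (0.46 log units; beyond the scatter), with some chance that only a limit is reached. The estimate for compound 4 is 45000 nM, from 15000 nM to 150000 nM.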

Compound 4, half-maximal inhibitory concentration: 99100 nM
For compound 4 the middle estimate is 2.2-fold (0.34 log units) below the measured one; low and high end bracket the measured number.
By their numbers in this assay, from the lowest: compounds 1 and 3 (each within the scatter of the next); then compound 4. At a limit, above all of these: compound 2.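

In this assay, going by these compounds alone, putting hydrogen in place of 4-methoxyphenyl gives a 6.3-fold higher number from compound 1 to compound 4 (0.80 log units; beyond the scatter) and so shows, as the earlier compounds could not, that this outer ring matters for the number reached. Its loss takes 8 heavy atoms away, but this single step cannot say which feature of the ring counts. Compound 4 also ends up close to the value at which compound 2 reaches a limit of the assay: the limit of > 100000 nM in this assay, at which 1 of the 4 values shown sits.

On these data alone, it remains open whether a pyridine ring or a cyclohexyl group at this place would restore the number of compound 1.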